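Replacing a nitro group on the shared core of compound 1

This account rests on a few compounds, and the source may have more. Where it says the series, first, only, none or still open, it means among the compounds named here.

Compound 1, `O=c1c2cc([N+](=O)[O-])cnc2sn1-c1ccc([N+](=O)[O-])cc1`, in an assay for inhibition of histone acetyltransferase KAT2B (Homo sapiens), read by fluorescence (a lower number here means a stronger inhibitor, a higher number a weaker inhibitor), gives 11800 nM. Compound 2, `O=c1c2cccnc2sn1-c1ccc([N+](=O)[O-])cc1`, gives 4100 nM. Compound 3, `O=c1ccsn1-c1ccc(Cl)c([N+](=O)[O-])c1`, gives 4800 nM.

Compound 1 stands highest of the three numbers in this assay. Compound 3 sits nearest to it, with a lower number that lies beyond the scatter, and compound 2 sits furthest, also with a lower number beyond the scatter. Compound 4, `COc1ccc(-n2sc3ncc([N+](=O)[O-])cc3c2=O)cc1`, has not yet been measured in this assay. It differs from compound 1 in one place: methoxy in place of nitro on an aromatic carbon.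

Within the data shown here, one measured step bears on this change. Going from compound 1 to compound 2, the nitro on the aromatic carbon is removed in favour of hydrogen, and the number falls: a 2.9-fold lower number from compound 1 to compound 2 (0.46 log units; beyond the scatter). Among the measured compounds shown here, compound 4 removes the same nitro but puts a methoxy in its place, and no measured pair shows what a methoxy at that carbon does on its own. For compound 4 the expected step is therefore a 2.6-fold lower number from compound 1 to compound 4 (0.42 log units; beyond the scatter), a lowering of similar modest size. The uncertainty of this expectation is wider than that of the measured step to compound 2. Compound 4 is accordingly estimated at 4500 nM, within a range from 1500 nM to 13000 nM.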

Compound 4, half-maximal inhibitory concentration: 3420 nM
Compound 4: the middle estimate sits 1.3-fold (0.12 log units) above what was measured, and the stated range covers the measured number.
By their numbers in this assay, from the lowest: compounds 4, 2 and 3 (each within the scatter of the next); then compound 1.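

The new step concerns the nitro group on the six-membered aromatic ring of carbon only, para to a large group, whereas the earlier step from compound 1 to compound 2 concerned the other nitro group of compound 1, the one on the shared core. In this assay, among these compounds, methoxy in place of nitro at this carbon gives a 3.5-fold lower number from compound 1 to compound 4 (0.54 log units; beyond the scatter) and so lies beyond the scatter, the first measured change at this position. The nitro at this carbon is therefore not needed for the measured inhibition, since compound 4 lacks it and still gives a lower number than compound 1. No measurement among these compounds gives a reason for this lower number.

The compounds shown leave open whether the lowering follows from the loss of the nitro or from the arrival of the methoxy, as none of them carries hydrogen at this carbon on the shared core of compound 1. On these data alone, how an amine, a carboxylic acid or a longer ether chain at the same carbon would compare with methoxy also remains open.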